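The source may hold more compounds than are shown below. What is called first, only, known or untested is meant among the compounds shown, and "the series" means these compounds.

In a functional assay on MOLM-13 cells (Homo sapiens) for antiproliferative activity (on this read-out higher numbers stand for weaker inhibition and lower numbers for stronger inhibition), three compounds sharing one core have been measured. Compound 1 (`Cc1c(-c2ccc(-c3ccccc3F)cc2)nc2ccc(F)cc2c1CO`), which carries hydroxymethyl, gives 700 nM. Compound 2 (`Cc1c(-c2ccc(-c3ccccc3F)cc2)nc2ccc(F)cc2c1-c1nnn[nH]1`), with 1H-tetrazol-5-yl in that place, returns only a limit, > 3000 nM. Compound 3 (`Cc1c(-c2ccc(-c3ccccc3F)cc2)nc2ccc(F)cc2c1C(=O)NC#N`), with cyanocarbamoyl there, also returns only a limit, > 3000 nM. Compound 3 therefore has no exact number and sits at the limit of > 3000 nM in this assay, at which 2 of the 3 values shown sit.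

Compound 4 (`Cc1c(-c2ccc(-c3ccccc3F)cc2)nc2ccc(F)cc2c1C(=O)NO`) has hydroxy in place of cyano on an amide-type nitrogen, turning cyanocarbamoyl into hydroxycarbamoyl: hydroxy in place of cyano on an amide-type nitrogen. For the measured compounds named here, no measured step makes this exact change. The nearest evidence is two steps away from hydroxymethyl, an at least 4.2-fold higher number from compound 1 to compound 2 (0.63 log units; beyond the scatter) and an at least 4.2-fold higher number from compound 1 to compound 3 (0.63 log units; beyond the scatter). The remaining step, a step that the two limits leave unreadable from compound 2 to compound 3, cannot be sized. Since compound 4 keeps the carbamoyl of compound 3, which gives > 3000 nM, it is expected to stay close to that limit, with any readable change small and toward a lower number. The expected step is an at least 1.2-fold lower number from compound 3 to compound 4 (0.07 log units; that floor lies within the scatter). The estimate for compound 4 is 2500 nM, within an expected range from 700 nM to 8000 nM.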

Compound 4, half-maximal inhibitory concentration: 23 nM
Compound 4: the middle estimate sits 110-fold (2.04 log units) above what was measured; measured number below the stated range.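

In this assay, putting hydroxy in place of cyano on the amide-type nitrogen gives an at least 130-fold lower number from compound 3 to compound 4 (2.11 log units; beyond the scatter), so a carbamoyl-based group at this aromatic carbon can carry strong activity, and the substituent on its nitrogen decides how much. Hydroxycarbamoyl also beats the other two groups held at that carbon, with an at least 130-fold lower number from compound 2 to compound 4 (2.11 log units; beyond the scatter) and a 30-fold lower number from compound 1 to compound 4 (1.48 log units; beyond the scatter), which makes compound 4 the most potent of the four. Compound 2 and compound 3 each return only a limit, so the two steps starting from them are floors rather than full sizes: the limit of > 3000 nM in this assay, at which 2 of the 4 values shown sit.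

On these data alone, how a methoxy or an amino group on that nitrogen, or a carboxylic acid on that aromatic carbon, would read remains open. The compounds shown also cannot say why hydroxy has this effect, or whether it would hold on a different core.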